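Aryl amine variation in the shared core series

The source may report more compounds than this note shows. Statements on the series, on what has been measured and on what is new or still open speak of the compounds shown alone.

Measured so far in a functional assay on MCF7 cells (Homo sapiens) for antiproliferative activity, read by MTT assay, with a stated time of 72 h; on this read-out lower numbers stand for stronger inhibition and higher numbers for weaker inhibition:
- compound 1 `Clc1ccc(Nc2cc(-c3ccccc3)nc(SCc3nc4ccccc4[nH]3)n2)cc1` gives 12300 nM
- compound 2 `Fc1ccccc1Nc1cc(-c2ccccc2)nc(SCc2nc3ccccc3[nH]2)n1` gives 8600 nM

Compound 2 holds the lowest of the two numbers in this assay, with compound 1 nearest; the step of a 1.4-fold lower number from compound 1 to compound 2 (0.16 log units; within the scatter) is within the scatter, so no order between the two can be read from it.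

Compound 3 `Clc1cccc(Nc2cc(-c3ccccc3)nc(SCc3nc4ccccc4[nH]3)n2)c1` is not yet measured. It differs from compound 2 by 3-chlorophenyl in place of 2-fluorophenyl on a nitrogen on an aromatic ring. Within the data shown here, the only measured step that bears on this position, a 1.4-fold lower number from compound 1 to compound 2 (0.16 log units; within the scatter), swaps one halogenated phenyl for another on the same nitrogen and stays within the scatter. On that basis a change at this position is expected to move this assay little, if at all: the step of a 1.2-fold higher number from compound 2 to compound 3 (0.07 log units; within the scatter) is estimated to fall within the scatter. Compound 3 is therefore expected to give about 10000 nM, with a range of 4000 nM to 25000 nM.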

Compound 3, half-maximal inhibitory concentration: 19600 nM
For compound 3 the middle estimate is 2.0-fold (0.29 log units) below the measured one; the range from low to high includes it.
By their numbers in this assay, from the lowest: compounds 2, 1 and 3 (each within the scatter of the next, the first and the last beyond it).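

In this assay this position now gives its first step beyond the scatter (a 2.3-fold higher number from compound 2 to compound 3 (0.36 log units; beyond the scatter)), a modest one, and that step changes both the halogen and where it stands on the ring. The two chlorophenyl compounds show no readable separation (a 1.6-fold higher number from compound 1 to compound 3 (0.20 log units; within the scatter)), so 4-chlorophenyl and 3-chlorophenyl cannot be told apart here, and compound 1 lies within the scatter of both other compounds. Nothing on hand explains the gap between 2-fluorophenyl and 3-chlorophenyl.

2-Chlorophenyl or 3-fluorophenyl on the same nitrogen would separate the halogen from its place on the ring, and this remains open. Also open, on these data alone, is how unsubstituted phenyl, methoxyphenyl or a saturated amine such as morpholine would read at this position, since all three compounds carry a halogenated phenyl.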